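Swapping an Ester for a Nitro Group: Cytotoxicity Outlook

The compounds below may be only part of what the source reports. "The series", "measured", "known", "first", "only" and "open" are said of these compounds alone.

Compound 3 `CCOC(=O)c1cnc(N2CCN(Cc3cccc(C(=O)OC)c3)CC2)nc1Oc1c(C)cc(-c2ccc(C#N)cc2)cc1C` carries a 3-(methoxycarbonyl)benzyl group on the amine nitrogen of its ring. In an ADME assay on MT4 cells (Homo sapiens) for cytotoxicity, read by MTT assay, with a stated time of 4 days (on this read-out lower numbers stand for higher toxicity in this test and higher numbers for lower toxicity in this test), compound 3 gives > 125000 nM, which is a limit of the assay rather than a measured number. Two neighbours share the same core and differ only in the aromatic ring attached to that benzylic carbon. Compound 1 `CCOC(=O)c1cnc(N2CCN(Cc3ccc(C#N)cc3)CC2)nc1Oc1c(C)cc(-c2ccc(C#N)cc2)cc1C` bears a 4-cyanophenyl there, and in this assay compound 1 gives > 125000 nM, again a limit and not a number. Compound 2 `CCOC(=O)c1cnc(N2CCN(Cc3ccccc3F)CC2)nc1Oc1c(C)cc(-c2ccc(C#N)cc2)cc1C` bears a 2-fluorophenyl, and in this assay compound 2 gives > 125000 nM, also a limit. Because all three values sit at the limit of > 125000 nM in this assay, at which 3 of the 3 values shown sit, the steps a step that the two limits leave unreadable from compound 1 to compound 2, a step that the two limits leave unreadable from compound 1 to compound 3 and a step that the two limits leave unreadable from compound 2 to compound 3 cannot be sized; they only show that none of these aromatic groups brought toxicity into the measurable window.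

Compound 4 `CCOC(=O)c1cnc(N2CCN(Cc3cccc([N+](=O)[O-])c3)CC2)nc1Oc1c(C)cc(-c2ccc(C#N)cc2)cc1C` is still to be measured. It differs from compound 3 in nitro in place of methoxycarbonyl on an aromatic carbon. Since every measured step at this position stayed beyond the limit, no change beyond the usual scatter is expected, and the step from compound 3 to compound 4 is estimated as a step that the limit leaves unreadable from compound 3 to compound 4. Compound 4 is therefore expected to give 150000 nM in this assay, with a range from 60000 nM to 400000 nM, most likely reported again only as a limit.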

Compound 4, half-maximal cytotoxic concentration: > 125000 nM
Compound 4: a limit, no number; the forecaster's own chance of this, stated with the estimate: 85%; the middle value is on the limit's open side.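

In this assay compound 4 gives > 125000 nM, a limit and not a number. Its steps to compound 1, compound 2 and compound 3 cannot be read, because all four compounds stop at the same limit: the limit of > 125000 nM in this assay, at which 4 of the 4 values shown sit.

The compounds shown leave open what the true cytotoxic concentration of each one is, and whether any group on this benzylic carbon would bring it into the measurable range.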